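The source may hold more compounds than are shown below. What is called first, only, known or untested is meant among the compounds shown, and "the series" means these compounds.

Measured compounds:
- compound 1, `CC1=C(C(=O)C2CC2)C(c2ccco2)NC(=O)N1`, 2% in an assay on membranes from CHO cells for displacement of a labelled ligand from adenosine receptor A1 (Homo sapiens), read by scintillation counting, with a stated time of 60 min, tested at 1 uM; a higher number here means more inhibition at the concentration tested (going by the name of the read-out), a lower number less inhibition
- compound 2, `CCN(CC)C(=O)C1=C(C)NC(=O)NC1c1ccco1`, 11% in this assay
- compound 3, `CCN(CC)C(=O)C1=C(C)NC(=O)NC1c1ccsc1`, 11% in this assay

Compound 2 sits level with compound 3 at the digits printed, the two together the highest of the three numbers, with compound 1 below it by a gap that stays within the scatter: a number 9 percentage points higher from compound 1 to compound 2 (within the scatter). The unmeasured compound 4, `CC1=C(C(=O)OCC2CCC2)C(c2ccco2)NC(=O)N1`, differs from compound 2 at the carbonyl carbon: cyclobutylmethoxy in place of diethylamino on a carbonyl carbon. Among the compounds with values here, the only measured step at that position is the one from compound 1 to compound 2, and it lay within the scatter; the step from compound 2 to compound 3, no change at the digits printed from compound 2 to compound 3 (within the scatter), concerns the saturated ring carbon and does not bear on this change. Within the data shown here, no step in this assay beyond the scatter is therefore expected for compound 4, with a number 3 percentage points lower from compound 2 to compound 4 (within the scatter) as the estimated step. Compound 4 is expected at 8%, in a range from -5% to 22%.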

Compound 4, a percentage reported as inhibition, at one concentration (the size of the read-out at that concentration, not a potency): 42%
Compound 4: the middle estimate sits 34 percentage points below what was measured; the whole stated range lies below it.
By their numbers in this assay, from the lowest: compounds 1, 2 and 3 (each within the scatter of the next); then compound 4.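

In this assay, within the data shown here, the carbonyl carbon proves to be a position that responds, which the earlier compounds did not show: cyclobutylmethoxy in place of diethylamino gives a number 31 percentage points higher from compound 2 to compound 4 (beyond the scatter) and cyclobutylmethoxy in place of cyclopropyl gives a number 40 percentage points higher from compound 1 to compound 4 (beyond the scatter). Both steps lie beyond the scatter, and both lead to the same group. No available measurement bears on why this change raises the number.

Open, on these data alone, is whether the gain follows the oxygen or the four-membered ring: a cyclobutylmethylamino group or an ethoxy group on this carbonyl carbon would separate the two. Also open, as far as these compounds go, is whether it holds with thiophen-3-yl on the saturated ring carbon.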